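The source may report more compounds than this note shows. Statements on the series, on what has been measured and on what is new or still open speak of the compounds shown alone.

In a functional assay on A549 cells (Homo sapiens) for inhibition, read by CCK-8 assay, with a stated time of 72 h, tested at 10 uM (on this read-out higher numbers stand for more inhibition of growth at the one concentration tested and lower numbers for less inhibition of growth), three compounds with a shared core, differing in the substituted phenyl group on an amide-type nitrogen, have been measured. Compound 1 (`CN(C)C(=O)c1cc2cnc(Nc3ccc(NC(=O)C4(C(=O)Nc5cccc(F)c5)CC4)cc3)nc2n1C1CCCC1`) gives 91.8% of inhibition, compound 2 (`CN(C)C(=O)c1cc2cnc(Nc3ccc(NC(=O)C4(C(=O)Nc5ccc(Br)cc5)CC4)cc3)nc2n1C1CCCC1`) gives 90.3% of inhibition, and compound 3 (`CN(C)C(=O)c1cc2cnc(Nc3ccc(NC(=O)C4(C(=O)Nc5cccc(C(F)(F)F)c5)CC4)cc3)nc2n1C1CCCC1`) gives 89.2% of inhibition. Compound 3 therefore sits within the usual scatter of both others. Compound 4 (`CN(C)C(=O)c1cc2cnc(Nc3ccc(NC(=O)C4(C(=O)Nc5ccc(C(F)(F)F)cc5)CC4)cc3)nc2n1C1CCCC1`) has the same atoms as compound 3, joined differently, with 4-(trifluoromethyl)phenyl in place of 3-(trifluoromethyl)phenyl on an amide-type nitrogen. The closest measured change in kind is 4-bromophenyl in place of 3-fluorophenyl, which gave a number 1.5 percentage points lower from compound 1 to compound 2 (within the scatter) as its step. The other two steps, a number 2.6 percentage points lower from compound 1 to compound 3 (within the scatter) and a number 1.1 percentage points lower from compound 2 to compound 3 (within the scatter), were just as small. None of these swaps left the scatter, so no step beyond the scatter is expected in this assay, and the expected move is a number 0.8 percentage points higher from compound 3 to compound 4 (within the scatter) at most a small one. The estimate for compound 4 is 90% as the expected value, with an expected range from 80% to 97% on this read-out.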

Compound 4, percent growth inhibition at one concentration: 87.9%
For compound 4 the middle estimate is 2.1 percentage points above the measured one; low and high end bracket the measured number.
By their numbers in this assay, from the lowest: compounds 4, 3, 2 and 1 (each within the scatter of the next).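

Moving the trifluoromethyl group, with 4-(trifluoromethyl)phenyl in place of 3-(trifluoromethyl)phenyl on the amide-type nitrogen, keeps the atoms the same and changes only how they are joined, and in this assay this gives a number 1.3 percentage points lower from compound 3 to compound 4 (within the scatter). Trifluoromethyl in place of bromo on an aromatic carbon gives a number 2.4 percentage points lower from compound 2 to compound 4 (within the scatter), and 4-(trifluoromethyl)phenyl in place of 3-fluorophenyl gives a number 3.9 percentage points lower from compound 1 to compound 4 (within the scatter), so the four substituted phenyl groups cannot be told apart on this read-out. Nothing available explains why these swaps leave the number so little changed.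

Going by these compounds, all four phenyl groups carry fluoro, bromo or trifluoromethyl, so it remains open whether an amine or a carboxylic acid on that ring would give a similar number. Also open, on these data alone, is whether the four compounds would stay this close at lower concentrations.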